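Swapping Hydroxy for Methyl on a Weak Inhibitor

A few compounds are considered here, and "the series" means these few. Any claim that something is new, unique, unknown or untested is made for them only; others in the source may bear on it.

Among the measured compounds shown here, in a functional assay on HCT-116 cells (Homo sapiens) for inhibition (a lower number here means a stronger inhibitor, a higher number a weaker inhibitor), compound 1 `Oc1ccc(/C=C/c2ccc3ccccc3c2)cc1` gives 4060 nM as its reading, the higher of the two numbers measured so far. Compound 2 `COc1cc(/C=C\c2ccc3ccccc3c2)ccc1F` gives 450 nM in this assay as its reading, a lower number by a margin beyond the scatter, which leaves compound 1 as the weaker inhibitor of the pair.

The next compound to be tested is compound 3 `Cc1ccc(/C=C/c2ccc3ccccc3c2)cc1`, which keeps the core of compound 1. The change methyl in place of hydroxy on an aromatic carbon puts methyl in place of hydroxy on an aromatic carbon, para to a large group. For the measured compounds named here, no measured pair shows this swap on its own, so the data offer no direct guide, and compound 1 at 4060 nM remains the only close reference. The estimated step of a 1.2-fold higher number from compound 1 to compound 3 (0.09 log units; within the scatter) is expected to stay within the scatter in this assay and, if anything, to lean toward a slightly higher number. For compound 3 the estimate is 5000 nM as the expected value, with an expected range from 1500 nM to 17000 nM around it.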

Compound 3, half-maximal inhibitory concentration: > 5000 nM
Compound 3: a limit, no number (the forecaster's own chance of this, stated with the estimate: 10%); the middle value lies on the limit itself.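

In this assay compound 3 gives > 5000 nM, which is a limit of the assay and not a number. Among the compounds shown here, the earlier compounds offered no pair with this swap alone, and methyl in place of hydroxy on an aromatic carbon, para to a large group, now reads as an at least 1.2-fold higher number from compound 1 to compound 3 (0.09 log units; that floor lies within the scatter); since that figure is only a floor, the true size of the step stays unknown. The swap therefore gave no stronger inhibitor at this position, even with the hydrogen-bond donor and acceptor of hydroxy gone, and the one fact that limits any further reading is this: the limit of > 5000 nM in this assay, at which 1 of the 3 values shown sits.

Going by these compounds, whether an amine or a carboxylic acid at this position would read differently from hydroxy and methyl remains open, as does the question of whether any group here could bring the core of compound 1 to a clearly lower number. Compound 2 differs from compound 1 in more than one place, so it cannot settle either question.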